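Moving the fluorine on the arylpiperazine amide

The source may report more compounds than this note shows. Statements on the series, on what has been measured and on what is new or still open speak of the compounds shown alone.

Among the compounds with values here, compound 2 `CCC(C(=O)N1CCN(c2ccc(F)cc2)CC1)N1C(=O)CCC1=O` stands lowest of the two numbers measured so far in a functional assay on the whole organism (strain Swiss) with Mus musculus as the target, in the maximal electroshock model, with a stated time of 0.25 h, at a dose of 300 mg/kg by the intraperitoneal route; on this read-out lower numbers stand for a weaker effect and higher numbers for a stronger effect at the one dose given: compound 2 gives 0%. Within the data shown here, its only neighbour is compound 1 `CCC(C(=O)N1CCN(c2ccccc2Cl)CC1)N1C(=O)CCC1=O`, which in this assay gives 50%, and the single measured step, a number 50 percentage points lower from compound 1 to compound 2 (beyond the scatter), changes the halogen and its ring position at once. Compound 3 `CCC(C(=O)N1CCN(c2ccccc2F)CC1)N1C(=O)CCC1=O` has not been measured; it differs from compound 2 as follows: 2-fluorophenyl in place of 4-fluorophenyl on an amine nitrogen in a ring. Among the measured compounds shown here, no measured pair isolates this change. The step that bears on it is a number 50 percentage points lower from compound 1 to compound 2 (beyond the scatter), which was large; compound 3 matches the 2-chlorophenyl of compound 1 in everything but the halogen, while keeping the fluorine of compound 2. A clear upward step is therefore expected, a number 25 percentage points higher from compound 2 to compound 3 (beyond the scatter). It is expected to fall short of the measured step, because compound 1 reaches 50% with chlorine rather than fluorine and the halogen itself was not tested alone. Compound 3 is estimated at 25%, within a range from 0% to 60%.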

Compound 3, a percentage reported as activity, at one dose (the size of the read-out at that dose, not a potency): 100%
For compound 3 the middle estimate is 75 percentage points below the measured one; measured number above the stated range.
By their numbers in this assay, from the lowest: compound 2; then compound 1; then compound 3.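

Compound 2 and compound 3 carry the same atoms and differ only in where the fluorine sits, and in this assay that single change gives a number 100 percentage points higher from compound 2 to compound 3 (beyond the scatter) on its own, which separates the effect of position from the effect of the halogen, something the earlier step could not do. With the position held as a 2-substituted phenyl on the amine nitrogen of the ring, the exchange of halogen gives a number 50 percentage points higher from compound 1 to compound 3 (beyond the scatter) and shows that the halogen matters as well, with fluoro ahead of chloro at this place in this pair. No measurement on these compounds offers any explanation for either step.

On these data alone, whether a bromine or a methoxy group at the place of the fluorine in the 2-fluorophenyl of compound 3 would keep this effect remains open, as does the fate of the effect with a longer chain on the carbon that bears the ring imide. As far as these compounds go, all three compounds are read at one dose and one stated time, so how compound 3 ranks at lower doses or at later times also stays unknown.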